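The compounds below may be only part of what the source reports. "The series", "measured", "known", "first", "only" and "open" are said of these compounds alone.

Of the compounds shown here, three from one series have been measured in an assay on membranes from HeLa cells for displacement of a labelled ligand from adenosine receptor A3 (Homo sapiens), read by scintillation counting, with a stated time of 180 min, tested at 1 uM; on this read-out higher numbers stand for more inhibition at the one concentration tested (going by the name of the read-out) and lower numbers for less inhibition. Compound 1, `CC1=C(C(=O)OC2CCCCC2)C(c2ccco2)NC(=O)N1`, gives 4% in this assay. Compound 2, `CC1=C(C(=O)OCC2CC2)C(c2ccco2)NC(=O)N1`, carries cyclopropylmethyl in place of cyclohexyl on an oxygen next to a carbonyl group and gives 1%; the step of a number 3 percentage points lower from compound 1 to compound 2 (within the scatter) lies within the scatter. Compound 3, `CC1=C(C(=O)OC2CCCCC2)C(c2ccsc2)NC(=O)N1`, carries thiophen-3-yl in place of furan-2-yl on a saturated ring carbon and gives 1%; the step of a number 3 percentage points lower from compound 1 to compound 3 (within the scatter) also lies within the scatter. Compound 3 and compound 2 show the same number at the digits printed, so nothing separates them here.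

Compound 4, `CC1=C(C(=O)OCC2CC2)C(c2ccsc2)NC(=O)N1`, has not been measured. It differs from compound 3 by cyclopropylmethyl in place of cyclohexyl on an oxygen next to a carbonyl group, the same change that was made from compound 1 to compound 2, and compound 3 and compound 1 differ by thiophen-3-yl in place of furan-2-yl on a saturated ring carbon. Because a number 3 percentage points lower from compound 1 to compound 2 (within the scatter) stayed within the scatter, and because compound 3 already gives 1%, the step of no change at the digits printed from compound 3 to compound 4 (within the scatter) is expected to be small as well. In this assay compound 4 is therefore estimated to give 1%, expected to fall between -5% and 8%.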

Compound 4, a percentage reported as inhibition, at one concentration (the size of the read-out at that concentration, not a potency): 3%
The estimate for compound 4 lay 2 percentage points below the measured number; low and high end bracket the measured number.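

In this assay, cyclopropylmethyl in place of cyclohexyl on an oxygen next to a carbonyl group gave a number 2 percentage points higher from compound 3 to compound 4 (within the scatter), and set beside the earlier step, this change showed no difference between the two cores that stands clear of the scatter: the same change on two cores in this assay, a number 3 percentage points lower (within the scatter) from compound 1 to compound 2 and a number 2 percentage points higher (within the scatter) from compound 3 to compound 4, 5 percentage points apart, within the scatter of two such steps. Thiophen-3-yl in place of furan-2-yl on a saturated ring carbon gave a number 2 percentage points higher from compound 2 to compound 4 (within the scatter), and this change likewise showed no such difference: the same change on two cores in this assay, a number 3 percentage points lower (within the scatter) from compound 1 to compound 3 and a number 2 percentage points higher (within the scatter) from compound 2 to compound 4, 5 percentage points apart, within the scatter of two such steps. For the compounds shown here, all of these steps lie within the scatter, so the agreement shows only that neither change produced a visible shift on either core; it does not show that a real effect of either change carries from one core to the other, or that the two changes add up.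

The compounds shown leave open whether any member of this series gives inhibition clearly beyond the scatter at the one concentration tested. As far as these compounds go, it also remains open whether an amine or a longer chain in place of cyclohexyl on that oxygen, or phenyl in place of furan-2-yl on the saturated ring carbon, would give a step large enough to compare between cores.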